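The compounds below may be only part of what the source reports. "The series", "measured", "known", "first", "only" and "open" are said of these compounds alone.

Measured compounds:
- compound 1, `COc1ccc(-c2c3ccc4ccccc4c3nc3c2c(C)nc2c4ccccc4ccc32)cc1`: 82.3 ug/mL
- compound 2, `Cc1nc2c3ccccc3ccc2c2nc3c(ccc4ccccc43)c(-c3cccc4ccccc34)c12`: 64.3 ug/mL
- compound 3, `Cc1nc2c3ccccc3ccc2c2nc3c(ccc4ccccc43)c(-c3cc([N+](=O)[O-])ccc3N)c12`: 43.3 ug/mL

The three compounds share one core and differ only in the aryl group attached to an aromatic carbon. In a functional assay, read by spectrophotometry, with a stated time of 15 min (on this read-out higher numbers stand for weaker inhibition and lower numbers for stronger inhibition), compound 1 gives 82.3 ug/mL, compound 2 gives 64.3 ug/mL and compound 3 gives 43.3 ug/mL. Every step between them stays within the scatter: a 1.3-fold lower number from compound 1 to compound 2 (0.11 log units; within the scatter), a 1.9-fold lower number from compound 1 to compound 3 (0.28 log units; within the scatter) and a 1.5-fold lower number from compound 2 to compound 3 (0.17 log units; within the scatter). Compound 3 therefore has the smallest of the three numbers, but neither its step from compound 2 nor its step from compound 1 rises beyond the scatter, so the three aryl groups cannot be told apart on these data.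

Compound 4, `Cc1nc2c3ccccc3ccc2c2nc3c(ccc4ccccc43)c(-c3ccccc3N)c12`, is not yet measured. It differs from compound 3 by hydrogen in place of nitro on an aromatic carbon. Going by the values given here, no measured step bears directly on this change: each of the three steps replaced the whole aryl group rather than removing a single substituent from it, and none of them moved the number beyond the scatter. With the whole aryl group making so little difference, removal of the nitro group alone is expected to leave the number where compound 3 stands, so the expected step is a 1.2-fold higher number from compound 3 to compound 4 (0.06 log units; within the scatter). Compound 4 is thus estimated at 50 ug/mL, with a range from 25 ug/mL to 100 ug/mL.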

Compound 4, half-maximal inhibitory concentration: 45.6 ug/mL
Beside the measured number, compound 4's estimate is 1.1-fold (0.04 log units) above it; measured number inside the range.
By their numbers in this assay, from the lowest: compounds 3, 4, 2 and 1 (each within the scatter of the next).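

In this assay, taking the nitro group off the 2-amino-5-nitrophenyl ring gives a 1.1-fold higher number from compound 3 to compound 4 (0.02 log units; within the scatter), and this is the first change shown that touches a single substituent at this position rather than replacing the whole aryl group. On these data the nitro group, para to the amino group, can therefore be lost without a step beyond the scatter, and the 2-aminophenyl group also stays within the scatter of the other aryl groups, with a 1.4-fold lower number from compound 2 to compound 4 (0.15 log units; within the scatter) and a 1.8-fold lower number from compound 1 to compound 4 (0.26 log units; within the scatter), so all four aryl groups at this carbon remain indistinguishable. No other measurement accompanies these numbers to account for this flat result.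

As far as these compounds go, what the amino group itself contributes stays open, as every comparison involving it also changes the rest of the aryl group, and a plain phenyl group at this carbon would separate its part from that of the ring. From the compounds shown here alone, it is also open whether any other group in the place of the nitro group, such as a carboxylic acid, a nitrile or a dimethylamino group, would move the number beyond the scatter.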